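A few compounds are considered here, and "the series" means these few. Any claim that something is new, unique, unknown or untested is made for them only; others in the source may bear on it.

Measured so far:
Compound 1, `CSc1ccc(NC(=O)Nc2cc(C)nc3ccccc23)cc1`, gives only a limit, > 25000 nM, in an ADME assay on BJ cells (Homo sapiens) for cytotoxicity, with a stated time of 72 h; on this read-out higher numbers stand for an effect only at larger amounts of compound and lower numbers for an effect already at smaller amounts.
Compound 2, `CSc1ccccc1NC(=O)Nc1cc(C)nc2ccccc12`, likewise gives only a limit, > 25000 nM, in this assay.
Compound 3, `Cc1cc(NC(=O)Nc2ccc(C(N)=O)cc2)c2ccccc2n1`, also gives only a limit, > 25000 nM, in this assay.

Compound 1 and compound 2 are built from the same atoms joined differently; the difference between their cores is not broken down here. From compound 1 to compound 3 the change is carbamoyl in place of methylsulfanyl on an aromatic carbon. The step it made, a step that the two limits leave unreadable from compound 1 to compound 3, cannot be read because of the limit of > 25000 nM in this assay, at which 3 of the 3 values shown sit.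

Compound 4, `Cc1cc(NC(=O)Nc2ccccc2C(N)=O)c2ccccc2n1`, has not yet been measured in this assay. It differs from compound 2 by carbamoyl in place of methylsulfanyl on an aromatic carbon. This is the same kind of change as that from compound 1 to compound 3, not the same one, since the place is ortho to a large group rather than para to a large group. The step from compound 2 to compound 4 is expected to be a step that the limit leaves unreadable from compound 2 to compound 4, set beside a step that the two limits leave unreadable from compound 1 to compound 3. That expectation rests on (the limit of > 25000 nM in this assay, at which 3 of the 3 values shown sit). For compound 4 in this assay the estimate is 30000 nM, most likely reported again only as a limit.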

Compound 4, half-maximal effective concentration in the BJ assay: > 25000 nM
Compound 4 gave a limit, no number (the forecaster's own chance of this, stated with the estimate: 85%); the middle value is on the limit's open side.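

In the BJ assay compound 2 gives only the limit > 25000 nM and no number. In the BJ assay compound 4 likewise gives only the limit > 25000 nM and no number. Within the data shown here, no step between them can be read. The compounds shown leave open at what amount any of them would affect these cells, and whether carbamoyl in place of methylsulfanyl on an aromatic carbon shifts that amount at all. In a physicochemical assay for solubility, at pH 7.4 (on this read-out higher numbers stand for higher solubility and lower numbers for lower solubility), compound 2 gives 21000 nM and compound 4 gives 200 nM as measured values, which makes a 110-fold lower number from compound 2 to compound 4 (2.02 log units; beyond the scatter) on this read-out.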